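This account rests on a few compounds, and the source may have more. Where it says the series, first, only, none or still open, it means among the compounds named here.

Within the data shown here, compound 2 `COc1cc(N(C)C)c(NC(=O)c2ccncc2)cc1Nc1nccc(-c2cn(C)c3ccccc23)n1` is one of two compounds measured in a functional assay on A549 cells (Homo sapiens) for antiproliferative activity, read by MTT assay, with a stated time of 72 h; a lower number here means a stronger inhibitor, a higher number a weaker inhibitor. In this assay compound 2 gives 9000 nM, and compound 1 `COc1cc(N(C)CCN(C)C)c(NC(=O)c2ccncc2)cc1Nc1nccc(-c2cn(C)c3ccccc23)n1` gives 10400 nM. Among the measured compounds shown here, the only measured step, a 1.2-fold lower number from compound 1 to compound 2 (0.06 log units; within the scatter), stays within the scatter, so compound 2 stands alongside compound 1 rather than apart from it.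

Compound 3 `COc1cc(N(C)C)c(NC(=O)c2ccccn2)cc1Nc1nccc(-c2cn(C)c3ccccc23)n1` differs from compound 2 by pyridin-2-yl in place of pyridin-4-yl on a carbonyl carbon. For the measured compounds named here, no measured step bears on this change: the step from compound 1 to compound 2 concerns the substituent on the aromatic nitrogen, not the carbonyl carbon, and it was itself within the scatter. With nothing to point either way, the expected step is none beyond the scatter. Compound 3 is therefore estimated to give 9000 nM in this assay, with a range from 3000 nM to 27000 nM. The step this estimate implies is no change at the digits printed from compound 2 to compound 3 (within the scatter), an expectation rather than a measurement.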

Compound 3, half-maximal inhibitory concentration: 8290 nM
Estimate against measurement, compound 3: 1.1-fold (0.04 log units) above; the range from low to high includes it.
By their numbers in this assay, from the lowest: compounds 3, 2 and 1 (each within the scatter of the next).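

Compound 1 and compound 2 differ only in the substituent on the aromatic nitrogen, whereas compound 3 differs from compound 2 in the group on the carbonyl carbon, and in this assay pyridin-2-yl in place of pyridin-4-yl gives a 1.1-fold lower number from compound 2 to compound 3 (0.04 log units; within the scatter). This single pair therefore shows that the two pyridinyl groups cannot be told apart in this assay, just as the substituents on the aromatic nitrogen could not be in compound 1 and compound 2. Nothing available explains why these two groups read alike.

As far as these compounds go, every group on this carbonyl carbon is a pyridinyl ring, so it remains open how pyridin-3-yl, a phenyl ring, a saturated amine such as piperidine or a short alkyl chain would read there. From the compounds shown here alone, it is equally open whether any change at this place would give a step beyond the scatter.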